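The source may report more compounds than this note shows. Statements on the series, on what has been measured and on what is new or still open speak of the compounds shown alone.

Working notes on the series. The shared core, shown for compound 1 `O=C(CSc1nc(Nc2ccccc2)c2ccccc2n1)Nc1ccccc1F` and compound 2 `O=C(CSc1nc(Nc2ccccc2)c2ccccc2n1)Nc1ccccc1Br`, carries an amide nitrogen bearing a halogenated phenyl group. In a functional assay on MGC-803 cells (Homo sapiens) for inhibition, read by MTT assay, with a stated time of 72 h (a lower number here means a stronger inhibitor, a higher number a weaker inhibitor), compound 1 gives 10700 nM and compound 2 gives 18600 nM. Going by the values given here, the only measured step so far is a 1.7-fold higher number from compound 1 to compound 2 (0.24 log units; within the scatter), so the two halogens at this position cannot be told apart on these numbers. Compound 2 stands with the highest of the two numbers, its nearest neighbour compound 1 sitting within the scatter of it.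

Compound 3 `O=C(CSc1nc(Nc2ccccc2)c2ccccc2n1)Nc1cccc(Cl)c1` is not yet measured in this assay. It differs from compound 2 by 3-chlorophenyl in place of 2-bromophenyl on an amide-type nitrogen. Among the compounds with values here, no measured step bears directly on moving the halogen to the other ring position; the one step available, from compound 1 to compound 2, exchanged halogens at a fixed position and stayed within the scatter. On that basis nothing larger than the scatter is expected in this assay, with no direction favoured. The step of a 1.2-fold lower number from compound 2 to compound 3 (0.09 log units; within the scatter) is therefore expected to stay within the scatter. For compound 3 the estimated value in this assay is 15000 nM, with a range from 5000 nM to 45000 nM.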

Compound 3, half-maximal inhibitory concentration: 14300 nM
For compound 3 the middle estimate is 1.0-fold (0.02 log units) above the measured one; measured number inside the range.
By their numbers in this assay, from the lowest: compounds 1, 3 and 2 (each within the scatter of the next).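

In this assay, 3-chlorophenyl in place of 2-bromophenyl on the amide-type nitrogen gives a 1.3-fold lower number from compound 2 to compound 3 (0.11 log units; within the scatter) and 3-chlorophenyl in place of 2-fluorophenyl gives a 1.3-fold higher number from compound 1 to compound 3 (0.13 log units; within the scatter). The earlier step exchanged halogens at a fixed ring position, whereas these two steps exchange the halogen and its ring position together, and the three halogenated phenyl groups still cannot be told apart on these numbers. No measurement accompanying the series bears on this result.

Because the halogen and its ring position change together in these steps, the separate contribution of each stays unresolved, and 2-chlorophenyl or 3-bromophenyl would be needed to separate them. Going by these compounds, all three compounds carry a halogenated phenyl group on the amide-type nitrogen, so it also remains open whether a phenyl group bearing an amine or a carboxylic acid, or a longer chain on that nitrogen, would give a step beyond the scatter in this assay.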